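The compounds below may be only part of what the source reports. "The series", "measured", "known", "first", "only" and "open" are said of these compounds alone.

The three compounds measured so far in an assay on 32D cells for inhibition of interleukin-15 (Mus musculus), read by resazurin assay, with stated times of 30 min and 2.5 days, in the presence of a further agent that is not named here; a lower number here means a stronger inhibitor, a higher number a weaker inhibitor:

compound 1 `Cn1c(Cc2nn(C)c(=O)c3ccccc23)nnc1SCCCCCCCC(=O)Nc1ccc(Cl)cc1Cl` gives 3900 nM
compound 2 `CN(C)CCCn1nc(Cc2nnc(SCC(=O)Nc3ccc(Cl)cc3Cl)n2C)c2ccccc2c1=O` gives 16700 nM
compound 3 `CN(C)CCCn1nc(Cc2nnc(SCCCCCCCC(=O)Nc3ccc(Cl)cc3Cl)n2C)c2ccccc2c1=O` gives 3200 nM

Compound 3 and compound 1 share the long chain between the sulfur and the amide and give numbers that lie within the usual scatter of each other. Compound 2, with a short chain in that position, gives a higher number than compound 3 by an amount beyond the scatter; since the two differ in more than the tail on the nitrogen, nothing further can be drawn from that pair.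

Compound 4 `Cn1c(Cc2nn(CCC=O)c(=O)c3ccccc23)nnc1SCCCCCCCC(=O)Nc1ccc(Cl)cc1Cl` keeps everything of compound 3 except the tail on the aromatic nitrogen: formyl in place of (dimethylamino)methyl on a saturated chain carbon, two bonds along the chain from an aromatic nitrogen. Among the compounds with values here, the only measured step that touches this tail is a 1.2-fold lower number from compound 1 to compound 3 (0.09 log units; within the scatter), where adding the whole basic chain hardly moved the reading. On that evidence the tail on this nitrogen seems to matter little, so the step is expected to be a 1.1-fold higher number from compound 3 to compound 4 (0.04 log units; within the scatter), without a clear direction. Compound 4 is therefore estimated at 3500 nM, within a range of 1500 nM to 9000 nM.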

Compound 4, half-maximal inhibitory concentration: 11700 nM
For compound 4 the middle estimate is 3.3-fold (0.52 log units) below the measured one, outside the stated range (above it).
By their numbers in this assay, from the lowest: compounds 3 and 1 (each within the scatter of the next); then compounds 4 and 2 (each within the scatter of the next).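

In this assay the change of (dimethylamino)methyl to formyl gives a 3.7-fold higher number from compound 3 to compound 4 (0.56 log units; beyond the scatter) on this chain, and formylmethyl in place of hydrogen gives a 3.0-fold higher number from compound 1 to compound 4 (0.48 log units; beyond the scatter) as well, so both comparisons point the same way. The tail on this aromatic nitrogen is therefore not free to vary: compound 1 and compound 3 read alike despite very different tails, yet the formyl-ended chain of compound 4 stands apart from both. No measured property of these compounds accounts for the gap.

Compound 4 cannot tell whether the formyl itself raises the number or whether any tail other than the dimethylamino-ended one would do so. A chain on this nitrogen ending in a hydroxyl, a carboxylic acid or a primary amine would help to separate these two readings.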